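Adding tert-butyl to compound 2: working notes

The compounds below may be only part of what the source reports. "The series", "measured", "known", "first", "only" and "open" are said of these compounds alone.

Measured in a functional assay on MCF7 cells (Homo sapiens) for antiproliferative activity, read by sulforhodamine B assay, with a stated time of 48 h; a higher number here means a weaker inhibitor, a lower number a stronger inhibitor:
- compound 1 `CCCCc1ccc(NS(=O)(=O)c2ccc(N3CCNC3=O)cc2)cc1`: 770 nM
- compound 2 `O=C1NCCN1c1ccc(S(=O)(=O)Nc2ccccc2)cc1`: 470 nM

Compound 2 has a single measured neighbour, compound 1, and the two values lie within the scatter of each other. The next compound to be tested is compound 3 `CC(C)(C)c1ccc(NS(=O)(=O)c2ccc(N3CCNC3=O)cc2)cc1`, which has tert-butyl in place of hydrogen on an aromatic carbon. That carbon belongs to a six-membered aromatic ring of carbon only and sits para to a large group.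

Within the data shown here, only one measured step bears on this change: a 1.6-fold lower number from compound 1 to compound 2 (0.21 log units; within the scatter), with hydrogen in place of butyl on an aromatic carbon. Read in reverse, it shows a butyl group entering, the closest available comparison for tert-butyl. That step lies within the scatter, so no step beyond the scatter is expected in this assay, with only a slight lean towards a higher number. The data hold no branched group for direct comparison. The expected step is a 1.4-fold higher number from compound 2 to compound 3 (0.14 log units; within the scatter). For compound 3 the estimated value is 650 nM, with an expected range of 280 nM to 1500 nM.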

Compound 3, half-maximal inhibitory concentration: > 1000 nM
Compound 3 ended at the assay's limit (the forecaster's own chance of this, stated with the estimate: 2%); at least 1.5-fold (0.18 log units) between middle value and limit.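

In this assay compound 3 gives > 1000 nM, which is a limit of the assay and not a number. On this aromatic carbon, para to a large group, tert-butyl in place of hydrogen gives an at least 2.1-fold higher number from compound 2 to compound 3 (0.32 log units; beyond the scatter), so this position now shows a change beyond the scatter, which the earlier pair did not show with a 1.6-fold lower number from compound 1 to compound 2 (0.21 log units; within the scatter). The comparison of the two four-carbon groups gives an at least 1.2-fold higher number from compound 1 to compound 3 (0.11 log units; that floor lies within the scatter), so the data do not separate tert-butyl from butyl at this position, and the contrast between the two steps from hydrogen rests on a floor rather than on two measured numbers.

Going by these compounds, how far compound 3 lies past the limit remains unknown, and with it the true size of both steps that end at compound 3. The compounds shown also leave open how methyl, methoxy, an amine or a carboxylic acid on this same aromatic carbon would read in this assay, and whether the change seen with tert-butyl would hold with any of them.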